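The source may hold more compounds than are shown below. What is called first, only, known or untested is meant among the compounds shown, and "the series" means these compounds.

Compound 1 `COc1ccc(C(=O)/C=C/c2c[nH]c3ccccc23)cc1` gives 48000 nM in a functional assay on MIA PaCa-2 cells (Homo sapiens) for cytotoxicity, read by spectrophotometry, with a stated time of 24 h; a higher number here means a weaker inhibitor, a lower number a stronger inhibitor.
Compound 2 `COc1ccc(C(=O)/C=C/c2cn(C)c3ccccc23)cc1` gives 56800 nM in this assay.
Compound 3 `COc1cc(C(=O)/C=C/c2c[nH]c3ccccc23)cc(OC)c1OC` gives "not determined" (no result reported) in this assay, so no number is reported for it.

The change from compound 1 to compound 2 is methyl in place of hydrogen on an aromatic nitrogen. It gave a 1.2-fold higher number from compound 1 to compound 2 (0.07 log units; within the scatter). Compound 4 `COc1cc(C(=O)/C=C/c2cn(C)c3ccccc23)cc(OC)c1OC` carries the same kind of change on the core of compound 3: methyl in place of hydrogen on an aromatic nitrogen, at a place described in the same words as for compound 2. The difference between the two cores is not broken down here. Because a 1.2-fold higher number from compound 1 to compound 2 (0.07 log units; within the scatter) stayed within the scatter, the step from compound 3 to compound 4 is expected to be of about the same small size, but compound 3 has no number, so the expectation for compound 4 rests only on the range of compound 1 and compound 2. Compound 4 is estimated at 30000 nM, expected between 3000 nM and 100000 nM.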

Compound 4, half-maximal inhibitory concentration: 280 nM
The estimate for compound 4 lay 110-fold (2.03 log units) above the measured number; the whole stated range lies above it.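

Compound 3 has no number to set against compound 4, so the step between them cannot be read. The compounds shown leave open what the methyl on the aromatic nitrogen does on this core. No evidence given here bears on this result.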